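Swapping the styryl arm for a trimethoxyphenyl on the pyrazoline

The source may report more compounds than this note shows. Statements on the series, on what has been measured and on what is new or still open speak of the compounds shown alone.

Of the compounds shown here, three have been tested in a functional assay on the whole organism (strain Wistar) for inhibition, with Rattus norvegicus as the target, read by paw edema, with stated times of 30 min and 5 h, at a dose of 20 mg/kg by the oral route; a lower number here means less inhibition, a higher number more inhibition at the dose given (going by the name of the read-out). Compound 1 `COc1ccc(C2CC(c3cc(Cl)c(C)cc3O)=NN2c2ccc(S(N)(=O)=O)cc2)c(OC)c1OC` gives 88.1%; compound 2 `COc1cc(C)c(Cl)cc1C1=NN(c2ccc(S(N)(=O)=O)cc2)C(c2cccc(O)c2)C1` gives 16.7%; compound 3 `COc1cc(C)c(Cl)cc1C1=NN(c2ccc(S(N)(=O)=O)cc2)C(/C=C/c2ccccc2)C1` gives 52.4%. Compound 3 thus stands second of the three, well above compound 2 and well below compound 1. Going by the values given here, the only single-point step measured so far, a number 35.7 percentage points higher from compound 2 to compound 3 (beyond the scatter), shows that what sits on the saturated ring carbon matters a great deal.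

Compound 4 `COc1cc(C)c(Cl)cc1C1=NN(c2ccc(S(N)(=O)=O)cc2)C(c2ccc(OC)c(OC)c2OC)C1` is not yet measured. It differs from compound 3 in one place: 2,3,4-trimethoxyphenyl in place of 2-phenylethenyl on a saturated ring carbon. The step from compound 2 to compound 3 bears on this only loosely, since it exchanged a different pair of groups at the same position. Compound 1, however, carries the same 2,3,4-trimethoxyphenyl group on its saturated ring carbon, and its high reading suggests that this group is compatible with strong inhibition. The step of a number 19.6 percentage points higher from compound 3 to compound 4 (beyond the scatter) is therefore expected to be upward and beyond the scatter. Compound 4 is estimated at 72%, with a range from 50% to 90%.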

Compound 4, a percentage reported as inhibition, in the whole organism at one dose (the size of the read-out at that dose, not a potency): 21.4%
Compound 4: middle estimate off by 50.6 percentage points, on the high side; the measured number lies below the stated range.
By their numbers in this assay, from the lowest: compounds 2 and 4 (each within the scatter of the next); then compound 3; then compound 1.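

In this assay the 2,3,4-trimethoxyphenyl group on the saturated ring carbon does not bring a high reading by itself, since replacing 2-phenylethenyl with it gives a number 31 percentage points lower from compound 3 to compound 4 (beyond the scatter) in this core. Exchanging 3-hydroxyphenyl for the same group gives only a number 4.7 percentage points higher from compound 2 to compound 4 (within the scatter) so these two aromatic groups cannot be told apart here, while 2-phenylethenyl stands clear of both. The largest change lies elsewhere, as a single methyl in place of hydrogen on an oxygen on an aromatic ring gives a number 66.7 percentage points lower from compound 1 to compound 4 (beyond the scatter) and so the high reading of compound 1 depends on that hydrogen.

No further data explain these steps. Still open, from the compounds shown here alone, is whether that hydrogen would raise the reading with 2-phenylethenyl in place, and how an amine or a carboxylic acid on the saturated ring carbon would read.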